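Swapping the amide tail: what solubility may follow

A few compounds are considered here, and "the series" means these few. Any claim that something is new, unique, unknown or untested is made for them only; others in the source may bear on it.

Compound 1 `COc1cc2nc(-c3ccccc3)nc(-n3nc(-c4ccccn4)nc3N)c2cc1OC`: 2000 nM
Compound 2 `COc1cc2ncnc(-n3nc(-c4ccccn4)nc3N)c2cc1OCCCNC(=O)CN1C[C@@H](C)O[C@@H](C)C1`: 34000 nM

In a physicochemical assay for solubility, in phosphate buffer, with a stated time of 18 h, at pH 7.4 (a lower number here means a less soluble compound, a higher number a more soluble compound), compound 2 gives 34000 nM, the higher of the two numbers. Compound 1 gives 2000 nM, a gap that lies beyond the scatter. Among the compounds with values here, no step between measured compounds differing in one place is available. Compound 3 `COc1cc2ncnc(-n3nc(-c4ccccn4)nc3N)c2cc1OCCCNC(=O)C(F)(F)F` differs from compound 2 in one place: trifluoromethyl in place of (2,6-dimethylmorpholin-4-yl)methyl on a carbonyl carbon. The number is expected to drop, with a 6.8-fold lower number from compound 2 to compound 3 (0.83 log units; beyond the scatter) expected to exceed the scatter. The estimate for compound 3 is 5000 nM, within a range from 1200 nM to 20000 nM.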

Compound 3, solubility: 1000 nM
Compound 3: the middle estimate sits 5.0-fold (0.70 log units) above what was measured; measured number below the stated range.
By their numbers in this assay, from the lowest: compounds 3 and 1 (each within the scatter of the next); then compound 2.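

In this assay, the group on the carbonyl carbon proves decisive on its own: trifluoromethyl in place of (2,6-dimethylmorpholin-4-yl)methyl gives a 34-fold lower number from compound 2 to compound 3 (1.53 log units; beyond the scatter), a large step. Within the data shown here, this is the first comparison in which only the amide tail differs, with the rest of the structure held constant. Nothing measured here accounts for the size of this step.

On these data alone, it remains open whether the change follows from losing the morpholine ring or from gaining trifluoromethyl. A methyl or a dimethylaminomethyl group on the same carbonyl carbon could help separate the two.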